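Chloro in place of methyl: compound 3 to compound 4

The source may report more compounds than this note shows. Statements on the series, on what has been measured and on what is new or still open speak of the compounds shown alone.

Compound 3 `Cc1ccc(Cc2cnc(CCc3ccc(-c4ccccc4C(=O)O)cc3)[nH]2)cc1` sits at the high end of the three measured compounds in an in vitro functional assay on cells for agonist activity at Bombesin receptor subtype-3 (Homo sapiens), read by luminescence and calcium flux (a higher number here means that more compound is needed for the effect, a lower number that less compound is needed), where compound 3 gives 2660 nM. Compound 1 `O=C(O)c1ccccc1-c1ccc(CCc2ncc(CC3CCC3)[nH]2)cc1` gives 588 nM, and compound 2 `CC(C)(C)CCc1cnc(CCc2ccc(-c3ccccc3C(=O)O)cc2)[nH]1` gives 39 nM; the steps of a 4.5-fold higher number from compound 1 to compound 3 (0.66 log units; beyond the scatter) and a 68-fold higher number from compound 2 to compound 3 (1.83 log units; beyond the scatter) are both beyond the scatter, so compound 3 needs the most compound of the three. Compound 4 `O=C(O)c1ccccc1-c1ccc(CCc2ncc(Cc3ccc(Cl)cc3)[nH]2)cc1` differs from compound 3 in one place: chloro in place of methyl on an aromatic carbon. Within the data shown here, none of the measured steps touches an aromatic carbon of that six-membered ring; each exchanges the whole group on the saturated chain carbon, as in a 15-fold lower number from compound 1 to compound 2 (1.18 log units; beyond the scatter). Among the measured compounds shown here, with no step bearing on this change, a shift of no more than the scatter is expected, a 1.3-fold lower number from compound 3 to compound 4 (0.12 log units; within the scatter). Compound 4 is therefore estimated at 2000 nM, with a range of 600 nM to 7000 nM.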

Compound 4, half-maximal effective concentration: 2290 nM
The estimate for compound 4 lay 1.1-fold (0.06 log units) below the measured number; the range from low to high includes it.
By their numbers in this assay, from the lowest: compound 2; then compound 1; then compounds 4 and 3 (each within the scatter of the next).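

In this assay, chloro in place of methyl, para to a large group on the aromatic ring, gives a 1.2-fold lower number from compound 3 to compound 4 (0.07 log units; within the scatter), so this exchange leaves the number unchanged within the scatter. The 4-chlorophenyl group also remains well short of the other two groups on the saturated chain carbon, with a 3.9-fold higher number from compound 1 to compound 4 (0.59 log units; beyond the scatter) and a 59-fold higher number from compound 2 to compound 4 (1.77 log units; beyond the scatter). Nothing available explains these results.

As far as these compounds go, whether methoxy, nitrile or an amine on that same aromatic carbon would also leave the number unchanged remains open. So does whether any substituent on this ring could bring the number close to that of compound 2.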